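Piperidin-1-yl Replaces an Open Amide Side Chain

The source may report more compounds than this note shows. Statements on the series, on what has been measured and on what is new or still open speak of the compounds shown alone.

In a functional assay on A549 cells (Homo sapiens) for inhibition, read by MTT assay, with a stated time of 72 h (on this read-out higher numbers stand for weaker inhibition and lower numbers for stronger inhibition), compound 1 `COc1ccccc1NC(=O)CCC(=O)OCCCCCCSc1ccc([N+](=O)[O-])c2nonc12` gives 1870 nM and compound 2 `CN(C)CCCNC(=O)CCC(=O)OCCCCCCSc1ccc([N+](=O)[O-])c2nonc12` gives 1580 nM, so these two stand level within the scatter. Compound 3 `O=C(CCC(=O)N1CCCCC1)OCCCCCCSc1ccc([N+](=O)[O-])c2nonc12` carries piperidin-1-yl in place of (3-(dimethylamino)propyl)amino on a carbonyl carbon. Within the data shown here, the one measured step at this part of the molecule, a 1.2-fold lower number from compound 1 to compound 2 (0.07 log units; within the scatter), stayed within the scatter. Among the measured compounds shown here, it is the only guide, and it involved no ring on that nitrogen. No step beyond the scatter is therefore expected in this assay. The expected change is a 1.1-fold higher number from compound 2 to compound 3 (0.06 log units; within the scatter). For compound 3 the estimated value is 1800 nM, with an expected range of 800 nM to 4000 nM.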

Compound 3, half-maximal inhibitory concentration: 2510 nM
The estimate for compound 3 lay 1.4-fold (0.14 log units) below the measured number, and the stated range covers the measured number.
By their numbers in this assay, from the lowest: compounds 2, 1 and 3 (each within the scatter of the next).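

In this assay piperidin-1-yl on this carbonyl carbon gives a 1.6-fold higher number from compound 2 to compound 3 (0.20 log units; within the scatter) and a 1.3-fold higher number from compound 1 to compound 3 (0.13 log units; within the scatter) and so stands level with both open side chains. This place therefore accepts a six-membered non-aromatic ring with 0 hydrogen-bond donors as readily as the two amino side chains that do carry the amide hydrogen. Nothing measured here offers an explanation for this result.

On these data alone, whether a carboxylic acid or a morpholine ring on this carbonyl carbon would also stay level remains open.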